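Cyano to Fluoro: Estimating a Cell Toxicity Value

The source may report more compounds than this note shows. Statements on the series, on what has been measured and on what is new or still open speak of the compounds shown alone.

Measured compounds in an ADME assay on MDCK cells (Canis lupus familiaris) for cytotoxicity, read by MTT assay, with a stated time of 24 h; on this read-out lower numbers stand for higher toxicity in this test and higher numbers for lower toxicity in this test:
- Compound 1 `Cc1cc(CNS(=O)(=O)c2ccc(C#N)cc2)c(C)s1`: > 217000 nM (a limit)
- Compound 2 `O=[N+]([O-])c1ccc(S(=O)(=O)NCc2csc3ccccc23)cc1`: > 191000 nM (a limit)
- Compound 3 `N#Cc1ccc(S(=O)(=O)NCc2csc3ccccc23)cc1`: 122000 nM

Compound 3 is the only one of the three with an actual number, at 122000 nM. The results for compound 1 and compound 2 are limits of the assay, so they cannot be ranked against it.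

The next candidate is compound 4 `O=S(=O)(NCc1csc2ccccc12)c1ccc(F)cc1`, which differs from compound 3 in one place: fluoro in place of cyano on an aromatic carbon.

For the measured compounds named here, only one measured step bears on this change, because it also involves cyano in that place: an at least 1.5-fold lower number from compound 2 to compound 3 (0.19 log units; that floor lies within the scatter). Going by the values given here, that step is a floor rather than a full size, and no measured step has fluoro entering. There is therefore no firm basis for predicting a direction in this assay, and no change beyond the usual scatter is expected. The estimated change is a 1.1-fold higher number from compound 3 to compound 4 (0.06 log units; within the scatter). For compound 4 the expected value is 140000 nM, with an estimated range of 75000 nM to 260000 nM.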

Compound 4, half-maximal cytotoxic concentration: 98600 nM
For compound 4 the middle estimate is 1.4-fold (0.15 log units) above the measured one; low and high end bracket the measured number.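

For the compounds shown here, for the first time at this position, para to a large group, a change can be sized with real numbers on both sides rather than only bounded: the swap of cyano for fluoro gives a 1.2-fold lower number from compound 3 to compound 4 (0.09 log units; within the scatter), so this assay does not tell these two groups apart. Nitro replaced by fluoro in the same place gives an at least 1.9-fold lower number from compound 2 to compound 4 (0.28 log units; that floor lies within the scatter). That step is only a floor, because compound 2 stands at a limit of the assay: the limit of > 191000 nM in this assay, at which 1 of the 4 values shown sits.

The compounds shown leave open whether any other group at this position, such as an amine, a carboxylic acid or a longer chain, would move the number beyond the scatter. Also open, going by these compounds, is whether fluoro would behave the same way on the core of compound 1, whose value is only a limit.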